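From pyridin-2-yl to pyridin-4-yl on a shared core

The source may report more compounds than this note shows. Statements on the series, on what has been measured and on what is new or still open speak of the compounds shown alone.

Of the compounds shown here, two have been tested in a functional assay on HeLa cells (Homo sapiens) for antiproliferative activity, read by CCK-8 assay, with a stated time of 72 h, tested at 8 uM; a lower number here means a weaker effect, a higher number a stronger effect of the compound at the concentration tested. Compound 1 `Nc1ccccc1NC(=O)c1ccc(CSC(=S)N2CCN(Cc3ccccn3)CC2)cc1` gives 61.4%. Compound 2 `Nc1ccccc1NC(=O)c1ccc(CSC(=S)N2CCc3ccc([N+](=O)[O-])cc32)cc1` gives 62.1%, a number within the scatter of compound 1, so neither stands apart from the other. Compound 3 `Nc1ccccc1NC(=O)c1ccc(CSC(=S)N2CCN(Cc3ccncc3)CC2)cc1` is not yet tested; it differs from compound 1 in one place: pyridin-4-yl in place of pyridin-2-yl on a saturated chain carbon bound to an amine nitrogen in a ring. Among the compounds with values here, no measured pair shows what such a change does here. The step of a number 1.4 percentage points lower from compound 1 to compound 3 (within the scatter) is therefore expected to stay within the scatter, in no particular direction. Compound 3 is estimated at 60%, with a range from 45% to 74%.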

Compound 3, a percentage reported as inhibition, at one concentration (the size of the read-out at that concentration, not a potency): 72.9%
Compound 3: middle estimate off by 12.9 percentage points, on the low side, within the range that was stated.
By their numbers in this assay, from the lowest: compounds 1 and 2 (each within the scatter of the next); then compound 3.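

In this assay, pyridin-4-yl in place of pyridin-2-yl gives a number 11.5 percentage points higher from compound 1 to compound 3 (beyond the scatter). The two groups have the same atoms and the same counts of hydrogen-bond donors and acceptors, so at this position the way those atoms are joined is enough to change the read-out. Nothing available explains this difference.

Going by these compounds, what pyridin-3-yl or a plain phenyl ring would give on the same chain carbon remains open. So does whether a longer chain between the piperazine nitrogen and the pyridin-4-yl ring would keep the higher number.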